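A few compounds are considered here, and "the series" means these few. Any claim that something is new, unique, unknown or untested is made for them only; others in the source may bear on it.

Measured in an ADME assay on microsomes from liver (Homo sapiens) for metabolic stability, read by LC-MS, with a stated time of 40 min, tested at 0.5 uM; on this read-out higher numbers stand for fast clearance and lower numbers for slow clearance:

- compound 1 `CC(C)(CO)S(=O)(=O)c1cccc(NC(=O)c2cccnc2N2CCC3(CC2)CC3)c1`: 154 mL.min-1.g-1
- compound 2 `CC(C)(C)NS(=O)(=O)c1cccc(NC(=O)c2ccc(NC(C)(C)CO)cc2N2CCC3(CC2)CC3)n1`: 189 mL.min-1.g-1
- compound 3 `CC(C)(C)NS(=O)(=O)c1cccc(NC(=O)c2cccnc2N2CCC3(CC2)CC3)c1`: > 399 mL.min-1.g-1 (a limit, not a number)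

Compound 3 gives no exact number in this assay and stands at the limit of > 399 mL.min-1.g-1 in this assay, at which 1 of the 3 values shown sits. Its value of > 399 mL.min-1.g-1 is a limit of the assay.

The next compound is compound 4 `O=C(Nc1cccc(S(=O)(=O)C2CCCC2)c1)c1cccnc1N1CCC2(CC1)CC2`, and the change is cyclopentyl in place of (tert-butyl)amino on a sulfonyl sulfur. In words, cyclopentyl stands in place of (tert-butyl)amino on a sulfonyl sulfur.

Among the compounds with values here, one measured step bears on this change. It is an at least 2.5-fold higher number from compound 1 to compound 3 (0.41 log units; beyond the scatter), which put the same (tert-butyl)amino on the sulfonyl sulfur in place of 1-(hydroxymethyl)-1-methylethyl. Within the data shown here, compound 2 differs from the others in more than one place and offers no step here.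

Compound 4 loses that amino group again, so a move to a lower number is expected, of about the size of the measured step or somewhat larger. The entering cyclopentyl is not the group that compound 1 carries, so this expectation is loose, and a second limit remains possible.

The expected change is an at least 1.5-fold lower number from compound 3 to compound 4 (0.18 log units; that floor lies within the scatter). For compound 4 the estimate is 260 mL.min-1.g-1, with an expected range from 110 mL.min-1.g-1 to 600 mL.min-1.g-1.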

Compound 4, intrinsic clearance in microsomes: > 399 mL.min-1.g-1
Compound 4: no number, only a limit (the forecaster's own chance of this, stated with the estimate: 30%); middle value at least 1.5-fold (0.18 log units) from the limit.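

In this assay compound 4 gives > 399 mL.min-1.g-1 as a limit of the assay and not as a number, so taking out the (tert-butyl)amino group did not bring the read-out back into the measured range: the limit of > 399 mL.min-1.g-1 in this assay, at which 2 of the 4 values shown sit. The step between compound 3 and compound 4 cannot be read, the two values both being limits. The step that can be read is an at least 2.5-fold higher number from compound 1 to compound 4 (0.41 log units; beyond the scatter) and it stands alongside an at least 2.5-fold higher number from compound 1 to compound 3 (0.41 log units; beyond the scatter) so the limit is reached with or without the nitrogen and its hydrogen-bond donor on the sulfonyl sulfur, and of the three groups seen at this place only 1-(hydroxymethyl)-1-methylethyl gives a measured number.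

On these data alone, how far apart compound 3 and compound 4 truly lie stays open, as does the question of whether the hydroxyl of 1-(hydroxymethyl)-1-methylethyl goes with the lower number or whether its branched carbon chain does. A plain tert-butyl or a hydroxycyclopentyl on the sulfonyl sulfur would separate these two readings, and the compounds shown include neither.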